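The source may report more compounds than this note shows. Statements on the series, on what has been measured and on what is new or still open speak of the compounds shown alone.

Within the data shown here, in a functional assay on A549 cells (Homo sapiens) for inhibition, read by CCK-8 assay, with a stated time of 48 h (a lower number here means a stronger inhibitor, a higher number a weaker inhibitor), compound 2 `COc1cc(-c2ccnc3cc(-c4ccc5ccn(C)c5c4)nn23)cc(OC)c1OC` gives 829 nM, the lower of the two numbers so far, while compound 1 `COc1cc(-c2ccnc3cc(-c4ccc(F)cc4)nn23)cc(OC)c1OC` gives 3800 nM. Among the measured compounds shown here, the two share one core, and the only measured step, a 4.6-fold lower number from compound 1 to compound 2 (0.66 log units; beyond the scatter), came with 1-methyl-1H-indol-6-yl in place of 4-fluorophenyl. Compound 3 `COc1cc(-c2ccnc3cc(-c4ccc(C(C)(C)C)cc4)nn23)cc(OC)c1OC` changes the same aromatic carbon, with 4-(tert-butyl)phenyl in place of 1-methyl-1H-indol-6-yl on an aromatic carbon. Like compound 1 at 3800 nM, compound 3 carries a phenyl group with one substituent, so much of that modest gain is expected to be lost. Nothing measured yet compares tert-butyl with fluorine, so the uncertainty stays wide. The expected change, an estimated rise in the number, is a 3.0-fold higher number from compound 2 to compound 3 (0.48 log units; beyond the scatter). For compound 3 the estimated value is 2500 nM, within a range of 800 nM to 8000 nM.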

Compound 3, half-maximal inhibitory concentration: > 10000 nM
Compound 3 was reported as a limit; the forecaster's own chance of this, stated with the estimate: 4%; at least 4.0-fold (0.60 log units) between middle value and limit.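

In this assay, compound 3 is reported only as a limit, not as an exact number: the limit of > 10000 nM in this assay, at which 1 of the 3 values shown sits. Replacing fluoro with tert-butyl on the phenyl group gives an at least 2.6-fold higher number from compound 1 to compound 3 (0.42 log units; beyond the scatter), so the substituent on that phenyl group matters, and the two phenyl compounds cannot be treated as alike. Replacing 1-methyl-1H-indol-6-yl with 4-(tert-butyl)phenyl gives an at least 12-fold higher number from compound 2 to compound 3 (1.08 log units; beyond the scatter), a larger gap than the one between the fluorophenyl and indolyl groups, which makes this aromatic carbon a sensitive place for change.

On these data alone, it remains open whether a phenyl group with a methoxy or an amine substituent would give a number closer to that of compound 2 or to the limit of compound 3. The compounds shown also cannot separate the contribution of the indole nitrogen from that of the second ring in compound 2.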